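Trimming one methoxy from the aryl on the carbonyl carbon

This account rests on a few compounds, and the source may have more. Where it says the series, first, only, none or still open, it means among the compounds named here.

Measured so far:
- compound 1 `COc1cc(-c2cc(/C=C/C(=O)c3ccc(Cl)c(Cl)c3)[nH]n2)cc(OC)c1OC` — 12800 nM
- compound 2 `COc1ccc(C(=O)/C=C/c2cc(-c3cc(OC)c(OC)c(OC)c3)n[nH]2)cc1OC` — 2660 nM

For the measured compounds named here, of the two numbers in a functional assay on RXF 393 cells (Homo sapiens) for inhibition, read by sulforhodamine B assay, with a stated time of 48 h (a lower number here means a stronger inhibitor of growth, a higher number a weaker inhibitor of growth), compound 2 holds the lower one; its nearest neighbour is compound 1, and the single measured step, a 4.8-fold lower number from compound 1 to compound 2 (0.68 log units; beyond the scatter), lies beyond the scatter. Both compounds share the same core and differ only in the aryl on the carbonyl carbon.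

Compound 3 `COc1ccc(C(=O)/C=C/c2cc(-c3cc(OC)c(OC)c(OC)c3)n[nH]2)cc1` is the next variation on that aryl. Its difference from compound 2 is hydrogen in place of methoxy on an aromatic carbon: the 3,4-dimethoxyphenyl of compound 2 becomes a 4-methoxyphenyl.

Going by the values given here, only one measured step bears on this position, and it exchanges the whole ring rather than a single methoxy; it shows that the group on the carbonyl carbon moves this assay by a modest margin, but gives no direct reading on removing one methoxy while keeping the other. The expectation is therefore a small shift, most likely toward a somewhat higher number, with a result within the scatter of compound 2 also plausible. The estimated step is a 1.5-fold higher number from compound 2 to compound 3 (0.18 log units; within the scatter). For compound 3 the estimate in this assay is 4000 nM, with a range from 1500 nM to 12000 nM.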

Compound 3, concentration for total growth inhibition: 2560 nM
Estimate against measurement, compound 3: 1.6-fold (0.19 log units) above; the measured number falls inside the stated range.
By their numbers in this assay, from the lowest: compounds 3 and 2 (each within the scatter of the next); then compound 1.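

In this assay the change from 3,4-dimethoxyphenyl to 4-methoxyphenyl on the carbonyl carbon gives a 1.0-fold lower number from compound 2 to compound 3 (0.02 log units; within the scatter), so this methoxy, ortho to a methoxy group and meta to a large group, can be replaced by hydrogen without a reading beyond the scatter. The exchange of the whole ring now has a second reading, a 5.0-fold lower number from compound 1 to compound 3 (0.70 log units; beyond the scatter), and it is close in size to a 4.8-fold lower number from compound 1 to compound 2 (0.68 log units; beyond the scatter), so among these three compounds the 3,4-dichlorophenyl stands apart while the two methoxy-bearing aryls cannot be told apart. No measurement on these compounds accounts for either the flat step or the gap to the 3,4-dichlorophenyl compound.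

Going by these compounds, what remains open is whether the methoxy left on the ring matters at all, which a plain phenyl would test, and whether a hydroxyl or an amine in its place would read differently. The step from compound 1 also changes two chlorines at once, so a 4-chlorophenyl would be needed to tell whether one chlorine alone carries the higher number.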